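The compounds below may be only part of what the source reports. "The series", "measured", "known", "first", "only" and "open" are said of these compounds alone.

Measured compounds:
compound 1 `COc1ccc(C2=NO[C@]3(C2)C(=O)O[C@@H]2[C@H]3CC[C@H](C)[C@]3(O)C=CC(=O)[C@@]23C)cc1`: 35000 nM
compound 2 `C[C@H]1CC[C@@H]2[C@@H](OC(=O)[C@]23CC(c2ccc(N(C)C)cc2)=NO3)[C@]2(C)C(=O)C=C[C@@]12O`: 6300 nM
compound 3 `Cc1cccc(C2=NO[C@]3(C2)C(=O)O[C@@H]2[C@H]3CC[C@H](C)[C@]3(O)C=CC(=O)[C@@]23C)c1`: 66600 nM

In a functional assay on PC-3 cells (Homo sapiens) for cytotoxicity, read by sulforhodamine B assay, with a stated time of 48 h (on this read-out lower numbers stand for stronger inhibition and higher numbers for weaker inhibition), compound 1 gives 35000 nM, the second highest of the three numbers. The nearest is compound 3 at 66600 nM; that gap is a 1.9-fold higher number from compound 1 to compound 3 (0.28 log units; within the scatter). The furthest is compound 2 at 6300 nM; that gap is a 5.6-fold lower number from compound 1 to compound 2 (0.74 log units; beyond the scatter).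

Compound 4 `C[C@H]1CC[C@@H]2[C@@H](OC(=O)[C@]23CC(c2ccc(C#N)cc2)=NO3)[C@]2(C)C(=O)C=C[C@@]12O` differs from compound 1 in one place.
cyano in place of methoxy on an aromatic carbon

Within the data shown here, the only measured step at the same aromatic carbon is a 5.6-fold lower number from compound 1 to compound 2 (0.74 log units; beyond the scatter), a different entering group. Among the measured compounds shown here, no measured step replaces methoxy with cyano, so no step beyond the scatter is expected in this assay: the expected step is a 1.1-fold higher number from compound 1 to compound 4 (0.06 log units; within the scatter). Compound 4 is estimated at 40000 nM, within 15000 nM to 110000 nM.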

Compound 4, half-maximal inhibitory concentration: 32000 nM
Beside the measured number, compound 4's estimate is 1.3-fold (0.10 log units) above it; low and high end bracket the measured number.
By their numbers in this assay, from the lowest: compound 2; then compounds 4, 1 and 3 (each within the scatter of the next, the first and the last beyond it).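

In this assay, cyano and methoxy on this aromatic carbon cannot be told apart (a 1.1-fold lower number from compound 1 to compound 4 (0.04 log units; within the scatter)), so the lower number of compound 2 stays with dimethylamino alone among the groups here (a 5.1-fold higher number from compound 2 to compound 4 (0.71 log units; beyond the scatter)). The 4-cyanophenyl group also separates, only just, from 3-methylphenyl (a 2.1-fold lower number from compound 3 to compound 4 (0.32 log units; beyond the scatter)), although compounds 1 and 3 lie within the scatter of each other. No evidence on the cause of these steps is available.

Open, on these data alone, is whether a primary amine or a carboxylic acid on this carbon would group with dimethylamino or with cyano and methoxy.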